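A few compounds are considered here, and "the series" means these few. Any claim that something is new, unique, unknown or untested is made for them only; others in the source may bear on it.

Compound 1 `Nc1cc(N)c2nc(-c3ccccc3)c(Oc3ccc(Cl)c(Cl)c3)nc2c1` — < 100000 nM
Compound 2 `CCOC(=O)[C@H](CCC(=O)O)NC(=O)c1ccc(Sc2nc3cc(N)cc(N)c3nc2-c2ccccc2)cc1` — < 100000 nM

The two measured compounds share a core and differ in the group attached to it. In a functional assay on NCI-H322M cells (Homo sapiens) for inhibition, read by sulforhodamine B assay, with a stated time of 48 h (on this read-out higher numbers stand for lower toxicity in this test and lower numbers for higher toxicity in this test), compound 1 gives < 100000 nM, and this value is a limit of the assay rather than a number. For compound 2 the result in this assay is < 100000 nM, again a limit and not a number. So compound 1 stands at the limit, and the whole picture of the measured compounds is given by the limit of < 100000 nM in this assay, at which 2 of the 2 values shown sit: neither value places a compound on the scale.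

The step to compound 3 `Nc1cc(N)c2nc(-c3ccccc3)c(Oc3ccc(F)cc3)nc2c1` is a single change at one place on the core: 4-fluorophenyl in place of 3,4-dichlorophenyl on an oxygen on an aromatic ring The new compound keeps the same oxygen link from the core to an aromatic ring.

For the measured compounds named here, no step between measured compounds exists to measure against, and both measured values sit at the same limit. Compound 3 is therefore expected to come out at or near that limit, with a step that the limit leaves unreadable from compound 1 to compound 3 expected, which is none beyond the usual scatter. The estimate for compound 3 in this assay is 70000 nM, expected between 15000 nM and 300000 nM.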

Compound 3, concentration lethal to 50% of the cells: 81300 nM
Beside the measured number, compound 3's estimate is 1.2-fold (0.06 log units) below it, and the stated range covers the measured number.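

In this assay, the change from compound 1 to compound 3 gives no step that can be read, because the result for compound 1 is a limit and not a number: the limit of < 100000 nM in this assay, at which 2 of the 3 values shown sit.

The compounds shown leave open how far 4-fluorophenyl and 3,4-dichlorophenyl, each on the oxygen, actually differ in this assay.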